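Chloro in place of cyano on compound 1

The source may hold more compounds than are shown below. What is called first, only, known or untested is meant among the compounds shown, and "the series" means these compounds.

Of the compounds shown here, two have been measured in an in vivo ADME assay on the whole organism (strain BALB/c) for pharmacokinetics, with Mus musculus as the target, read by LC-MS, at a dose of 5 mg/kg by the oral route; a lower number here means that a smaller share of the oral dose reaches the circulation, a higher number that a larger share of the oral dose reaches the circulation. Compound 1 (`CC(C)c1ccc(S(C)(=O)=O)cc1C#Cc1cc(C#N)ccc1OCC(=O)O`) gives 26%, and compound 2 (`COCCNS(=O)(=O)c1ccc(C)c(C#Cc2cc(Cl)ccc2OCC(=O)O)c1`) gives 33%. For the measured compounds named here, these two values lie within the usual scatter of each other, so the numbers do not separate the compounds, and compound 1 cannot be ranked against the only other compound measured.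

Compound 3 (`CC(C)c1ccc(S(C)(=O)=O)cc1C#Cc1cc(Cl)ccc1OCC(=O)O`) keeps the core of compound 1 and differs in one place: chloro in place of cyano on an aromatic carbon, para to a carboxymethoxy group (chloro in place of cyano on an aromatic carbon). Going by the values given here, no pair of measured compounds differs in just one place, so the data hold no direct evidence of how such an exchange plays out in this assay. With nothing to suggest a direction, no change beyond the scatter is expected, and the expectation is anchored on compound 1 at 26%. The estimated step, a number 4 percentage points higher from compound 1 to compound 3 (within the scatter), therefore stays within the scatter. For compound 3 the expected value is 30%, with an estimated range from 14% to 48%.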

Compound 3, oral bioavailability: 29%
The estimate for compound 3 lay 1 percentage points above the measured number, and the stated range covers the measured number.
By their numbers in this assay, from the lowest: compounds 1, 3 and 2 (each within the scatter of the next).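

In this assay, for the compounds shown here, the exchange of cyano for chloro on the aromatic carbon para to a carboxymethoxy group provides the first comparison in the set of two compounds that differ in one place, and it reads a number 3 percentage points higher from compound 1 to compound 3 (within the scatter). On the core of compound 1, then, this position accepts a chloro in place of a cyano, a swap of two heavy atoms for one and of one hydrogen-bond acceptor for none, without a change that the numbers can separate from the usual scatter. The data offer no measurement that would explain this outcome.

The compounds shown leave open whether the same holds for other groups at this position, such as a methoxy, an amine or a carboxylic acid, since only cyano and chloro have been read there, and only on this core. They also leave open how the rest of the structure bears on the oral exposure, since compound 2 differs from compound 3 in more than one place and so gives no clean comparison with it.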